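Methoxy in place of trifluoromethoxy on a shared core

A few compounds are considered here, and "the series" means these few. Any claim that something is new, unique, unknown or untested is made for them only; others in the source may bear on it.

Measured compounds:
compound 1, `O=c1[nH]c(-c2cccc3ccccc23)nc2ccc(N3CCCCC3)cc12`, in a functional assay on HCT-15 cells (Homo sapiens) for cytotoxicity, read by MTT assay, with a stated time of 2 days; on this read-out lower numbers stand for stronger inhibition and higher numbers for weaker inhibition: 2240 nM
compound 2, `Cc1ccc2c(=O)[nH]c(-c3ccccc3N(C)C)nc2c1`: 12800 nM
compound 3, `Cc1ccc2c(=O)[nH]c(-c3cccc(OC(F)(F)F)c3)nc2c1`: > 50000 nM

Compound 1 and compound 2 both give numbers in this assay. Among the compounds with values here, compound 3 stands apart: its value in this assay is a limit and not a number, and it is the one value among the three that sits at the limit of > 50000 nM in this assay, at which 1 of the 3 values shown sits. Within the data shown here, compounds 1 and 2 differ from compound 3 in more than one place, so no single step between measured compounds can be read from them.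

Compound 4, `COc1cccc(-c2nc3cc(C)ccc3c(=O)[nH]2)c1`, has not yet been measured in this assay. It differs from compound 3 by methyl in place of trifluoromethyl on an oxygen on an aromatic ring. Because compound 3 sits at the limit of > 50000 nM in this assay, at which 1 of the 3 values shown sits, any improvement would have to be large before a number appears. Among the measured compounds shown here, the change is small in the count of atoms, and no measured step in this assay shows what it does. Compound 4 is therefore expected to stay close to where compound 3 is, with a step of an at least 1.2-fold lower number from compound 3 to compound 4 (0.09 log units; that floor lies within the scatter) that, if it exists, leans toward stronger inhibition but may well stay within the scatter. The estimate for compound 4 in this assay is 40000 nM, between 10000 nM and 150000 nM.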

Compound 4, half-maximal inhibitory concentration: 4850 nM
Compound 4: the middle estimate sits 8.2-fold (0.92 log units) above what was measured; the measured number lies below the stated range.
By their numbers in this assay, from the lowest: compound 1; then compound 4; then compound 2. At a limit, above all of these: compound 3.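

In this assay, the change from trifluoromethoxy to methoxy on the shared core brings an at least 10-fold lower number from compound 3 to compound 4 (1.01 log units; beyond the scatter), which shows that this position responds strongly to what is carried on the oxygen. The size of this step is a floor and not an exact figure, because the value of compound 3 is a limit and not a number: the limit of > 50000 nM in this assay, at which 1 of the 4 values shown sits. This single pair shows the size of the effect of the change but not which feature of the exchange lies behind it, and steps linking compound 1 or compound 2 to the others cannot be read.

From the compounds shown here alone, it remains open whether a free hydroxyl or an ethyl chain on the same oxygen would lower the number further or raise it again, and whether an amine in place of the methoxy would hold the gain. Going by these compounds, it is also open whether the change from trifluoromethoxy to methoxy would have a step of similar size on the core of compound 1, or in cells other than those of this assay.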